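A Methyl Added to the Benzylic Ring of Compound 1

The compounds below may be only part of what the source reports. "The series", "measured", "known", "first", "only" and "open" are said of these compounds alone.

For the measured compounds named here, compound 1 `Nc1nc(NCc2ccccc2)nc(-c2c(F)cccc2CO)n1` is the one compound of this set for which a number is reported in a functional assay on cells for positive allosteric modulation of G-protein coupled receptor 68 (Homo sapiens), read by a luciferase reporter and cAMP accumulation, with a stated time of 30 min, at pH 6.8 and pH 8.3, in the presence of a further agent that is not named here (on this read-out higher numbers stand for higher potency (the scale is a negative logarithm) and lower numbers for lower potency), where compound 1 gives 3.69. A second compound, compound 2 `COc1cccc(CO)c1-c1nc(N)nc(NCc2ccccc2)n1`, was tested in the same assay but returned only a qualitative outcome: compound 2 gives "not active" (no number reported) in this assay, so no number stands beside it and nothing about the size of its difference from compound 1 can be stated. The account now follows the step from compound 1 to compound 3 `Cc1cccc(CNc2nc(N)nc(-c3c(F)cccc3CO)n2)c1`, which has not yet been measured in this assay. The change is methyl in place of hydrogen on an aromatic carbon. Going by the values given here, no step between two measured compounds is available to calibrate such a change, and the single number for compound 1 is low on the scale. Such a small change is expected to move the read-out at most modestly, most likely by no more than the usual scatter, with a slight lean upward, so that compound 3 is expected to give 3.9, in the range 3.4 to 4.5, corresponding to an expected step of a number 0.21 log units higher from compound 1 to compound 3 (within the scatter).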

Compound 3, negative logarithm of the antagonist equilibrium constant: 4.44
The estimate for compound 3 lay 0.54 log units below the measured number; the measured number falls inside the stated range.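

For the compounds shown here, the step of a number 0.75 log units higher from compound 1 to compound 3 (beyond the scatter) in this assay is the first change in this set that can be given a size, and it lies beyond the usual scatter. It shows that the benzyl ring of the core of compound 1 is not a silent place on this read-out: going from benzyl to 3-methylbenzyl, with one carbon added on an aromatic carbon meta to a large group, is enough to produce a measurable gain, though the values remain low on the scale. Nothing at hand says why this single methyl has that effect.

What the compounds shown leave open is whether the gain belongs to methyl specifically or would also appear with an ethyl group, a chlorine atom, a methoxy group, an amine or a carboxylic acid at the same place, and whether methyl on the other carbons of that ring would do the same. They also leave open whether the same methyl would bring a measurable number to compound 2, which has none.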